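A few compounds are considered here, and "the series" means these few. Any claim that something is new, unique, unknown or untested is made for them only; others in the source may bear on it.

Compound 1 `NNc1nonc1/C(=N/O)Nc1ccc(F)c(Br)c1` and compound 2 `O=S(=O)(CCNc1nonc1/C(=N/O)Nc1ccc(F)c(Br)c1)NCC1CC1` share a core and differ only in what hangs off its amino group. In an assay on HeLa cells for inhibition of Indoleamine 2,3-dioxygenase 1 (Homo sapiens), read by spectrophotometry, with a stated time of 24 h (a higher number here means that more compound is needed for the effect, a lower number that less compound is needed), compound 1 gives 556 nM, while compound 2 gives 268 nM, the lower of the two numbers, and its distance from compound 1 lies beyond the usual scatter. Compound 3 `O=S(=O)(CCNc1nonc1/C(=N/O)Nc1ccc(F)c(Br)c1)NO` keeps the sulfonamide chain of compound 2 and changes one end: hydroxy in place of cyclopropylmethyl on a sulfonamide nitrogen. For the measured compounds named here, no measured pair shows this exact change, so the step in this assay is expected to be small, with no clear direction beyond the scatter, as a 1.1-fold lower number from compound 2 to compound 3 (0.03 log units; within the scatter). Compound 3 is therefore estimated at 250 nM, within a range from 80 nM to 800 nM.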

Compound 3, half-maximal effective concentration: > 800 nM
Compound 3 gave a limit, no number (the forecaster's own chance of this, stated with the estimate: 5%); at least 3.2-fold (0.50 log units) between middle value and limit.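

At this end of the sulfonamide chain, hydroxy in place of cyclopropylmethyl gives an at least 2.9-fold higher number from compound 2 to compound 3 (0.47 log units; beyond the scatter) in this assay, so the number responds to this group, which the small expected step did not anticipate. The other step reads an at least 1.4-fold higher number from compound 1 to compound 3 (0.15 log units; that floor lies within the scatter), so compound 3 is not shown to sit apart from compound 1. On these data alone, compound 3 gave a limit, not a number, so the full size of both steps stays unknown: the limit of > 800 nM in this assay, at which 1 of the 3 values shown sits. Open, as far as these compounds go, is whether a carboxylic acid, an amine or a longer carbon chain at this nitrogen would keep the number of compound 2, or lower it.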